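The source may hold more compounds than are shown below. What is called first, only, known or untested is meant among the compounds shown, and "the series" means these compounds.

Working notes on the series.

Compound 2 `Cc1cc(Oc2ccc(-c3ccn(CCC(C)C)c(=O)c3C#N)cc2)ccn1` is the current point of departure. In a functional assay on CHO cells for positive allosteric modulation of metabotropic glutamate receptor 2 (Homo sapiens), read by scintillation counting and GTPgammaS binding, with a stated time of 30 min (on this read-out higher numbers stand for an effect only at larger amounts of compound and lower numbers for an effect already at smaller amounts), compound 2 gives 447 nM; this is the higher of the two numbers in hand, the other being compound 1 `CC(C)CCn1ccc(-c2ccc(OCC3CC3)cc2)c(C#N)c1=O`, which in this assay gives 290 nM. Among the measured compounds shown here, the step of a 1.5-fold higher number from compound 1 to compound 2 (0.19 log units; within the scatter) is the only measured step so far, and it concerns the group on the oxygen, not the chain on the aromatic nitrogen.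

Compound 3 `Cc1cc(Oc2ccc(-c3ccn(CC4CCC4)c(=O)c3C#N)cc2)ccn1` differs from compound 2 by cyclobutyl in place of isobutyl on a saturated chain carbon bound to an aromatic nitrogen. For the measured compounds named here, no measured step touches the chain on the aromatic nitrogen, so nothing in the data speaks to the size or direction of this change. Going by the values given here, the only step available, from compound 1 to compound 2, lies within the scatter, and the two numbers in hand sit close together.

Among the compounds with values here, with no step bearing on the change, compound 3 is expected to show no step beyond the scatter, so a 1.0-fold higher number from compound 2 to compound 3 (0.00 log units; within the scatter) is estimated to be small. Compound 3 is therefore estimated at 450 nM in this assay, with a plausible range from 150 nM to 1400 nM.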

Compound 3, half-maximal effective concentration: 126 nM
Compound 3: middle estimate off by 3.6-fold (0.55 log units), on the high side, and the stated range ends above it.
By their numbers in this assay, from the lowest: compound 3; then compounds 1 and 2 (each within the scatter of the next).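

Among the compounds shown here, the chain on the aromatic nitrogen proves to be a place where the number in this assay responds: a 3.5-fold lower number from compound 2 to compound 3 (0.55 log units; beyond the scatter) is the first measured step beyond the scatter, whereas the only earlier step, at the group on the oxygen, stayed within it. The change leaves the count at 4 heavy atoms, all carbon, with 0 hydrogen-bond donors and 0 hydrogen-bond acceptors on either side, so in this one pair the lower number goes with a four-membered non-aromatic ring in place of open, branched isobutyl rather than with any difference in those counts. Nothing measured in hand accounts for the step.

Open, going by these compounds, is whether the ring itself or its size carries the step, a question that a cyclopropyl or cyclopentyl group on the same saturated chain carbon, or a longer open chain such as n-pentyl, would address. For the compounds shown here, also open is whether the step holds with cyclopropylmethyl in place of 2-methylpyridin-4-yl on the oxygen, since compound 1 is the only compound here with that group and it carries the isopentyl chain.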